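Replacing 4-Bromo-3-chlorophenyl with 2,4-Difluorophenyl on the Sulfonamide Nitrogen

The source may hold more compounds than are shown below. What is called first, only, known or untested is meant among the compounds shown, and "the series" means these compounds.

Of the compounds shown here, three sharing one core have been measured in a functional assay on cells (leukaemia cell line, Homo sapiens) for inhibition, read by sulforhodamine B assay, with a stated time of 48 h; a higher number here means a weaker inhibitor of growth, a lower number a stronger inhibitor of growth. Compound 1 `O=S(=O)(Nc1ccc(Cl)c(Cl)c1)c1ccc(-c2cnc(C3CC3)o2)cc1` gives 62100 nM, compound 2 `O=S(=O)(Nc1ccc(F)c(Cl)c1)c1ccc(-c2cnc(C3CC3)o2)cc1` gives 73700 nM, and compound 3 `O=S(=O)(Nc1ccc(Br)c(Cl)c1)c1ccc(-c2cnc(C3CC3)o2)cc1` gives 70300 nM. Compound 3 therefore cannot be separated from the other two, as a 1.1-fold higher number from compound 1 to compound 3 (0.05 log units; within the scatter) and a 1.0-fold lower number from compound 2 to compound 3 (0.02 log units; within the scatter) show. The remaining pair behaves the same way, with a 1.2-fold higher number from compound 1 to compound 2 (0.07 log units; within the scatter).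

The next compound is compound 4 `O=S(=O)(Nc1ccc(F)cc1F)c1ccc(-c2cnc(C3CC3)o2)cc1`, in which 2,4-difluorophenyl stands in place of 4-bromo-3-chlorophenyl on a sulfonamide nitrogen: 2,4-difluorophenyl in place of 4-bromo-3-chlorophenyl on a sulfonamide nitrogen. The measured steps bear on this change only in part. Both a 1.2-fold higher number from compound 1 to compound 2 (0.07 log units; within the scatter) and a 1.1-fold higher number from compound 1 to compound 3 (0.05 log units; within the scatter) exchange one halogen for another, and both stay within the scatter. Within the data shown here, compound 4, however, is the only one of the four without a chloro group, and no measured step shows what losing it does. The flat series gives no reason to expect a step beyond the scatter, although this change is larger than any measured so far. The expected step is a 1.1-fold higher number from compound 3 to compound 4 (0.03 log units; within the scatter). In this assay, compound 4 is estimated at 75000 nM, with an expected range from 45000 nM to 100000 nM.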

Compound 4, concentration for total growth inhibition: 66100 nM
The estimate for compound 4 lay 1.1-fold (0.05 log units) above the measured number; measured number inside the range.
By their numbers in this assay, from the lowest: compounds 1, 4, 3 and 2 (each within the scatter of the next).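

In this assay, among these compounds, the step to compound 4 removes the chloro group that all the earlier compounds carry, and the number still does not move beyond the scatter: the change gives a 1.1-fold lower number from compound 3 to compound 4 (0.03 log units; within the scatter) and the replacement of 3-chloro-4-fluorophenyl gives a 1.1-fold lower number from compound 2 to compound 4 (0.05 log units; within the scatter), while the replacement of 3,4-dichlorophenyl gives a 1.1-fold higher number from compound 1 to compound 4 (0.03 log units; within the scatter). The earlier steps shown here exchanged only one halogen for another, whereas this result shows that the whole aryl group on the sulfonamide nitrogen can change, from 4-bromo-3-chlorophenyl to 2,4-difluorophenyl, with no step that can be told from repeat measurement, so all four compounds remain indistinguishable in this assay. Nothing available here offers an explanation for why the four compounds read alike.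

As far as these compounds go, all four compounds carry only halogens on this aryl group, so it remains open whether the flat picture would survive an unsubstituted phenyl, a methoxy group, an amine or a carboxylic acid at this place. From the compounds shown here alone, what a change elsewhere in the shared core would do also stays open, as that core is the same in all four.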